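Changing the aryl group on the ring nitrogen of a shared core

The source may report more compounds than this note shows. Statements on the series, on what has been measured and on what is new or still open speak of the compounds shown alone.

compound 1 `O=C(/C=C/c1ccc(O)c(O)c1)N1CCN(c2ccc(F)cc2)CC1` — 1.44 ug/mL
compound 2 `O=C(/C=C/c1ccc(O)c(O)c1)N1CCN(c2ccccc2Cl)CC1` — 1.36 ug/mL
compound 3 `O=C(/C=C/c1ccc(O)c(O)c1)N1CCN(c2cccc(Cl)c2)CC1` — 1.34 ug/mL

In a functional assay on MCF7 cells (Homo sapiens) for antiproliferative activity, read by MTT assay, with a stated time of 48 h (on this read-out lower numbers stand for stronger inhibition and higher numbers for weaker inhibition), compound 1 stands at the high end of the three numbers, yet all three lie within the usual scatter of one another: the steps of a 1.1-fold lower number from compound 1 to compound 2 (0.02 log units; within the scatter) and a 1.1-fold lower number from compound 1 to compound 3 (0.03 log units; within the scatter) are both within it, and so is a 1.0-fold lower number from compound 2 to compound 3 (0.01 log units; within the scatter). Compound 4 `Cc1ccc(N2CCN(C(=O)/C=C/c3ccc(O)c(O)c3)CC2)c(C)c1` differs from compound 1 by 2,4-dimethylphenyl in place of 4-fluorophenyl on an amine nitrogen in a ring. Every measured step also exchanges the aryl group in this same place, and none of them moved the number beyond the scatter, so no step beyond the scatter is expected here either. Compound 4 is therefore estimated at 1.4 ug/mL, with a range from 0.7 ug/mL to 2.8 ug/mL. The step of a 1.0-fold lower number from compound 1 to compound 4 (0.01 log units; within the scatter) that this estimate implies is expected to stay within the scatter.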

Compound 4, half-maximal inhibitory concentration: 0.78 ug/mL
The estimate for compound 4 lay 1.8-fold (0.25 log units) above the measured number; the range from low to high includes it.
By their numbers in this assay, from the lowest: compounds 4, 3, 2 and 1 (each within the scatter of the next).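

In this assay, within the data shown here, the 2,4-dimethylphenyl group, the first aryl group here with methyl groups and no halogen, stays within the scatter of all three earlier compounds: a 1.8-fold lower number from compound 1 to compound 4 (0.27 log units; within the scatter), a 1.7-fold lower number from compound 2 to compound 4 (0.24 log units; within the scatter) and a 1.7-fold lower number from compound 3 to compound 4 (0.24 log units; within the scatter). These are the largest steps seen so far at this position, but none goes beyond the scatter, so this place on the ring nitrogen accepts a halogen-free aryl group without a clear shift. Nothing measured here bears on these steps. Still open, on these data alone, is whether an aryl group carrying a carboxylic acid or an amine, or a plain alkyl chain in place of the aryl group, would produce a step beyond the scatter.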